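Chloro in Place of Hydrogen Across Two Related Cores

The source may hold more compounds than are shown below. What is called first, only, known or untested is meant among the compounds shown, and "the series" means these compounds.

Of the compounds shown here, three have been tested in a functional assay on A549 cells (Homo sapiens) for antiproliferative activity, read by MTT assay, with a stated time of 24 h; a higher number here means a weaker inhibitor, a lower number a stronger inhibitor. Compound 1, with the structure `COc1ccc(C2CC(c3ccccc3)=NN2c2ccc(-c3ccccc3)nn2)cc1`, gives 91700 nM in this assay. Compound 2, with the structure `COc1ccc(C2CC(c3ccc(Cl)cc3)=NN2c2ccc(-c3ccccc3)nn2)cc1`, carries chloro in place of hydrogen on an aromatic carbon and gives 100000 nM in this assay. The step of a 1.1-fold higher number from compound 1 to compound 2 (0.04 log units; within the scatter) therefore does not separate the two. Compound 3, with the structure `COc1ccc(C2=NN(c3ccc(-c4ccccc4)nn3)C(c3ccccc3)C2)cc1`, has the same atoms as compound 1 joined differently; the difference between the two cores is not broken down here. In this assay compound 3 gives 75900 nM, which lies within the scatter of both compound 1 and compound 2, so no order among the three can be read from these numbers.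

Compound 4, with the structure `COc1ccc(C2=NN(c3ccc(-c4ccccc4)nn3)C(c3ccc(Cl)cc3)C2)cc1`, has not yet been measured. It differs from compound 3 by chloro in place of hydrogen on an aromatic carbon, the same change that leads from compound 1 to compound 2, and at a place described in the same words. The expectation for compound 4 rests on that one earlier step, a 1.1-fold higher number from compound 1 to compound 2 (0.04 log units; within the scatter), which was within the scatter, and on the value of compound 3, 75900 nM. The estimated step of a 1.1-fold higher number from compound 3 to compound 4 (0.04 log units; within the scatter) is accordingly expected to be small. Compound 4 is thus expected to give about 83000 nM in this assay, with a likely range from 38000 nM to 180000 nM.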

Compound 4, half-maximal inhibitory concentration: 100000 nM
Compound 4: the middle estimate sits 1.2-fold (0.08 log units) below what was measured, and the stated range covers the measured number.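

In this assay the new step, a 1.3-fold higher number from compound 3 to compound 4 (0.12 log units; within the scatter), does not separate the two compounds, so chloro in place of hydrogen leaves no readable mark on this core, just as it left none on the core of compound 1. Set side by side, the two steps do not differ, and as far as these numbers go the change carries from one core to the other: the same change on two cores in this assay, a 1.1-fold higher number (0.04 log units; within the scatter) from compound 1 to compound 2 and a 1.3-fold higher number (0.12 log units; within the scatter) from compound 3 to compound 4, 1.2-fold (0.08 log units) apart, within the scatter of two such steps. This does not show that chloro is without effect in general, since the comparison rests on one change, phenyl to 4-chlorophenyl, on two cores, and the agreement is between two steps that are both too small to read, which says nothing about whether a step large enough to be seen would also carry over.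

The compounds shown leave open whether a different group at that place on the aromatic ring, such as an amine or a carboxylic acid, would give a step beyond the scatter on either core. Also open, from the compounds shown here alone, is what happens on each core when the methoxy group that all four compounds share gives way to a hydroxyl or a longer chain such as butoxy.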